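This account rests on a few compounds, and the source may have more. Where it says the series, first, only, none or still open, it means among the compounds named here.

The measured compounds:
Compound 1 `CCCn1c(=O)c2nc(-c3ccc(OCC(=O)NCCN=C(S)Nc4ccc(OC)cc4)cc3)[nH]c2n(CCC)c1=O`: 33.2 nM
Compound 2 `CCCn1c(=O)c2nc(-c3ccc(OCC(=O)NCCNS(=O)(=O)c4ccc(C)cc4)cc3)[nH]c2n(CCC)c1=O`: 72 nM

In an assay on brain for binding affinity to adenosine receptor A1 (Rattus norvegicus), read by radioligand binding (a higher number here means a weaker inhibitor, a lower number a stronger inhibitor), compound 1 gives 33.2 nM, while compound 2 gives 72 nM. Compound 2 thus stands at the higher of the two measured numbers. Among the measured compounds shown here, the only measured step is a 2.2-fold higher number from compound 1 to compound 2 (0.34 log units; beyond the scatter), a change of the terminal group on the chain, and it was modest.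

Compound 3 `CCCn1c(=O)c2nc(-c3ccc(OCC(=O)NCCNC(=O)c4ccc(CBr)cc4)cc3)[nH]c2n(CCC)c1=O` differs from compound 2 by (4-(bromomethyl)phenyl)carbonyl in place of (4-methylphenyl)sulfonyl on an amine nitrogen. For the measured compounds named here, this alters the same distal region that the measured step touched, so that step is the only guide; no measured compound carries the group that enters. The reviewer therefore expects a change no larger than the one seen, and leans toward a somewhat lower number, because compound 1 with a different terminal group gave 33.2 nM. Compound 3 is expected to give 45 nM, in the range 15 nM to 150 nM. The expected step is a 1.6-fold lower number from compound 2 to compound 3 (0.20 log units; within the scatter).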

Compound 3, inhibition constant: 11.5 nM
The estimate for compound 3 lay 3.9-fold (0.59 log units) above the measured number, and the stated range ends above it.
By their numbers in this assay, from the lowest: compound 3; then compound 1; then compound 2.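

In this assay, among the compounds shown here, the change at this amine nitrogen moved the number further down than the earlier compounds had suggested (a 6.3-fold lower number from compound 2 to compound 3 (0.80 log units; beyond the scatter)), showing that the terminal group on the chain can lower the number as well as raise it. The (4-(bromomethyl)phenyl)carbonyl group also outdoes the terminal group of compound 1 (a 2.9-fold lower number from compound 1 to compound 3 (0.46 log units; beyond the scatter)), which leaves compound 3 with the lowest number of the three, its steps to both others being beyond the scatter. Nothing available here accounts for this result.

The compounds shown leave open which part of the exchange carries the step, the carbonyl for the sulfonyl or the bromomethyl for the methyl. A (4-methylphenyl)carbonyl group on the same nitrogen would separate the two, and a 4-chloromethyl or 4-hydroxymethyl group would test the bromine itself.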